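Swapping the ring on the hydrazone carbon once more

The source may hold more compounds than are shown below. What is called first, only, known or untested is meant among the compounds shown, and "the series" means these compounds.

Compound 2 `CN(C)CCn1cnnc1-c1cc(Oc2ccc(NC(=O)N/N=C/c3ccc(O)c(O)c3)cc2F)ccn1` is the weaker of the two measured compounds: in a functional assay on MKN-45 cells (Homo sapiens) for cytotoxicity, read by MTT assay, with a stated time of 72 h (a lower number here means a stronger inhibitor, a higher number a weaker inhibitor), compound 2 gives 3240 nM, the highest number of the two, whereas compound 1 `CN(C)CCn1cnnc1-c1cc(Oc2ccc(NC(=O)N/N=C/c3c(Cl)cccc3Cl)cc2F)ccn1` gives 160 nM. Among the compounds with values here, the single measured step, a 20-fold higher number from compound 1 to compound 2 (1.31 log units; beyond the scatter), shows that exchanging the aryl group on this carbon can shift the result a great deal. Compound 3 `Cc1cc(/C=N/NC(=O)Nc2ccc(Oc3ccnc(-c4nncn4CCN(C)C)c3)c(F)c2)cc(C)c1O` differs from compound 2 at the same place: 4-hydroxy-3,5-dimethylphenyl in place of 3,4-dihydroxyphenyl on a carbon with a double bond to nitrogen. The new group is neither of the two already measured, so that step only shows the size that such an exchange can reach, not its direction here. A change in either direction, possibly beyond the scatter, is therefore plausible, with a wide range. For compound 3 in this assay the estimate is 1000 nM, between 250 nM and 4000 nM, which would mean a 3.2-fold lower number from compound 2 to compound 3 (0.51 log units; beyond the scatter).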

Compound 3, half-maximal inhibitory concentration: 1510 nM
Estimate against measurement, compound 3: 1.5-fold (0.18 log units) below; measured number inside the range.
By their numbers in this assay, from the lowest: compound 1; then compound 3; then compound 2.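

In this assay, exchanging 3,4-dihydroxyphenyl for 4-hydroxy-3,5-dimethylphenyl gives a 2.1-fold lower number from compound 2 to compound 3 (0.33 log units; beyond the scatter), so this position still responds when a hydroxyl-bearing ring is kept and its other groups are changed. The gain recovers only part of the earlier loss: 4-hydroxy-3,5-dimethylphenyl in place of 2,6-dichlorophenyl gives a 9.4-fold higher number from compound 1 to compound 3 (0.97 log units; beyond the scatter), and both hydroxyl-bearing rings shown remain well behind the dichlorinated ring. No measurement here explains these differences between the rings.

The compounds shown cannot separate the effect of removing the ring hydroxyl from that of adding chlorine, since no ring here carries only methyl groups or only one chlorine. A 4-methoxyphenyl group or a pyridine ring on this carbon also remains an open case.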